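A few compounds are considered here, and "the series" means these few. Any claim that something is new, unique, unknown or untested is made for them only; others in the source may bear on it.

Measured in a functional assay on K562 cells (Homo sapiens), read by MTT assay, with a stated time of 72 h; on this read-out lower numbers stand for stronger inhibition and higher numbers for weaker inhibition:
- compound 1 `C#Cc1cn([C@@H]2O[C@H](CO)[C@@H](O)[C@H]2O)c2ncnc(OC)c12`: 380 nM
- compound 2 `COc1ncnc2c1c(-c1cccs1)cn2[C@@H]1O[C@H](CO)[C@@H](O)[C@H]1O`: 6200 nM
- compound 3 `COc1ncnc2c1c(-c1ccco1)cn2[C@@H]1O[C@H](CO)[C@@H](O)[C@H]1O`: 380 nM

Compound 1 stands level with compound 3 at the digits printed, the two together giving the lowest numbers of the three; its nearest neighbour is compound 3 and the furthest is compound 2, a 16-fold higher number from compound 1 to compound 2 (1.21 log units; beyond the scatter). The change from compound 2 to compound 3 is a 16-fold lower number from compound 2 to compound 3 (1.21 log units; beyond the scatter), and from compound 1 to compound 3 it is no change at the digits printed from compound 1 to compound 3 (within the scatter).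

Compound 4 `C#Cc1cn([C@@H]2O[C@H](CO)[C@@H](O)[C@H]2O)c2ncnc(N(C)C)c12` differs from compound 1 at another site altogether: dimethylamino in place of methoxy on an aromatic carbon. None of the three measured steps touches this position; all of them vary the group on the five-membered ring while the methoxy stays fixed. Going by the values given here, no measured step therefore bears on the change to compound 4, and the size and direction of its effect on this assay cannot be read from the series. Taking compound 1 as the only anchor, the expectation for compound 4 is a modest weakening, with wide uncertainty, a 2.1-fold higher number from compound 1 to compound 4 (0.32 log units; beyond the scatter). Compound 4 is estimated at 800 nM, with a range of 150 nM to 4500 nM.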

Compound 4, half-maximal inhibitory concentration: 260 nM
The estimate for compound 4 lay 3.1-fold (0.49 log units) above the measured number; the measured number falls inside the stated range.
By their numbers in this assay, from the lowest: compounds 4, 1 and 3 (each within the scatter of the next); then compound 2.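

In this assay, the position next to the ring nitrogen, held as methoxy in compound 1, compound 2 and compound 3, now has a measured step: a 1.5-fold lower number from compound 1 to compound 4 (0.16 log units; within the scatter). With ethynyl kept, dimethylamino therefore reads as level with methoxy here, a contrast with the other site, where thiophen-2-yl in place of ethynyl gave a 16-fold higher number from compound 1 to compound 2 (1.21 log units; beyond the scatter). No measurement on these compounds accounts for the two groups reading alike.

Two groups at this position do not define its limits: a primary amine, a longer ether such as butoxy or a cyclic amine such as morpholine could still shift the number. From the compounds shown here alone, whether dimethylamino stays level with methoxy when furan-2-yl or thiophen-2-yl replaces ethynyl also remains open.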